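Weak growth inhibition and the step to compound 3

The compounds below may be only part of what the source reports. "The series", "measured", "known", "first", "only" and "open" are said of these compounds alone.

Compound 1 `O=C(Nc1nccs1)c1cccc(Nc2ncc(F)c(Nc3ccc(F)cc3)n2)c1`: > 10000 nM as a limit and not a number
Compound 2 `O=C(Nc1cc(Cl)cc(Cl)c1)c1cccc(Nc2ncc(F)c(Nc3ccc(F)cc3)n2)c1`: 20700 nM as a number

Going by the values given here, in a functional assay on KBVIN cells (Homo sapiens) for antiproliferative activity, read by sulforhodamine B assay, with a stated time of 3 days (on this read-out higher numbers stand for weaker inhibition of growth and lower numbers for stronger inhibition of growth), compound 2 gives 20700 nM and this is the only true number available. Compound 1 gives > 10000 nM in this assay and that value is a limit. Compound 2 therefore has no exact value to be ranked against.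

Compound 3 `COCC(=O)Nc1cccc(Nc2ncc(F)c(Nc3ccc(F)cc3)n2)c1` has not yet been measured. The change from compound 2 is ((methoxymethyl)carbonyl)amino in place of (3,5-dichlorophenyl)carbamoyl on an aromatic carbon and so ((methoxymethyl)carbonyl)amino stands in place of (3,5-dichlorophenyl)carbamoyl on an aromatic carbon.

Among the compounds with values here, only one measured step is available, a step that the limit leaves unreadable from compound 1 to compound 2 and it concerns a different change on the amide-type nitrogen. Going by these compounds, its size stays unknown because the limit of > 10000 nM in this assay, at which 1 of the 2 values shown sits, is all that is known on the side of compound 1. It therefore gives no guide to size or direction, and the expectation rests on compound 2 at 20700 nM as the starting point. No step beyond the scatter is expected, and the estimate is a 1.4-fold lower number from compound 2 to compound 3 (0.14 log units; within the scatter) in this assay as a cautious expectation. For compound 3 the expected value is 15000 nM with an estimated range from 4000 nM to 45000 nM in this wide guess.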

Compound 3, concentration for 50% growth inhibition: 3940 nM
For compound 3 the middle estimate is 3.8-fold (0.58 log units) above the measured one; measured number outside the range, below it.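

In this assay, this aromatic carbon, meta to a large group, now proves to be a place where a change moves growth inhibition beyond the scatter: ((methoxymethyl)carbonyl)amino, which has no ring, in place of (3,5-dichlorophenyl)carbamoyl, which carries a six-membered aromatic ring of carbon only, gives a 5.3-fold lower number from compound 2 to compound 3 (0.72 log units; beyond the scatter). The same entering group in place of (1,3-thiazol-2-yl)carbamoyl gives an at least 2.5-fold lower number from compound 1 to compound 3 (0.40 log units; beyond the scatter), so the change points the same way from both ring-bearing carbamoyl groups. The value of compound 1 is a limit, which makes this second step a bound and not a measured size: the limit of > 10000 nM in this assay, at which 1 of the 3 values shown sits.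

Since the ring, the carbamoyl link and the methoxy oxygen all change together, the compounds shown do not tell which of these carries the step from compound 2 to compound 3. Going by these compounds, how a plain amine, a carboxylic acid or a longer chain ending in a methoxy group would behave on this aromatic carbon remains open, as does whether any group there can go further than compound 3.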